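Three flat analogues and a longer chain on the core

A few compounds are considered here, and "the series" means these few. Any claim that something is new, unique, unknown or untested is made for them only; others in the source may bear on it.

In a functional assay on PANC-1 cells (Homo sapiens) for inhibition, read by MTT assay, with a stated time of 24 h, tested at 10 uM (on this read-out higher numbers stand for more inhibition at the one concentration tested (going by the name of the read-out) and lower numbers for less inhibition), compound 1 `COc1ccc(NC(=O)Oc2cc(=O)n(CCCO)c3c2CC(CC=C(C)C)C(C)(C)C3)cc1` gives 0%. Compound 2 `COc1ccccc1NC(=O)Oc1cc(=O)n(CCCO)c2c1CC(CC=C(C)C)C(C)(C)C2` gives 0% in this assay, and compound 3 `CC(C)=CCC1Cc2c(OC(=O)Nc3ccc(Cl)cc3)cc(=O)n(CCCO)c2CC1(C)C` gives 0%. The measured steps are all flat: no change at the digits printed from compound 1 to compound 2 (within the scatter), no change at the digits printed from compound 1 to compound 3 (within the scatter) and no change at the digits printed from compound 2 to compound 3 (within the scatter). For the measured compounds named here, compound 1 therefore stands level with compounds 2 and 3, with nothing so far rising above the scatter.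

Compound 4 `COc1ccc(NC(=O)Oc2cc(=O)n(CCCO)c3c2CC(C/C=C(\C)CCC=C(C)C)C(C)(C)C3)cc1` differs from compound 1 by 3-methylbut-2-en-1-yl in place of hydrogen on a saturated chain carbon bound to a double-bonded chain carbon. Going by the values given here, none of the measured steps touches this part of the molecule; all three concern the aryl group on the amide-type nitrogen, and each was without effect within the scatter. Among the compounds with values here, no measured step bears directly on the change from compound 1 to compound 4, so the expectation rests only on the flat baseline of the series. The estimated step is a number 5 percentage points higher from compound 1 to compound 4 (within the scatter), expected to stay within the scatter. Compound 4 is estimated at 5%, within the range 0% to 22%.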

Compound 4, a percentage reported as inhibition, at one concentration (the size of the read-out at that concentration, not a potency): 0%
Estimate against measurement, compound 4: 5 percentage points above, within the range that was stated.
By their numbers in this assay, from the lowest: compounds 1, 2, 3 and 4 (each within the scatter of the next).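

In this assay, the first change away from the aryl group on the amide-type nitrogen, 3-methylbut-2-en-1-yl in place of hydrogen on a saturated chain carbon bound to a double-bonded chain carbon, gives no change at the digits printed from compound 1 to compound 4 (within the scatter). Compound 1 already stands at 0%, so the step shows only that extending 3-methylbut-2-en-1-yl to 3,7-dimethylocta-2,6-dien-1-yl brings no inhibition into view at the one concentration tested, and it gives no measure of what this position can lose. No supporting data bear on this flat result.

Open, on these data alone, is whether a chain at this position ending in an amine or a carboxylic acid would rise above the scatter. Also open is how any of these compounds reads at another concentration.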